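A few compounds are considered here, and "the series" means these few. Any claim that something is new, unique, unknown or untested is made for them only; others in the source may bear on it.

Measured so far in a functional assay on MCF7 cells (Homo sapiens) for cytotoxicity, read by MTT assay, with a stated time of 48 h; on this read-out lower numbers stand for stronger inhibition and higher numbers for weaker inhibition:

- compound 1 `O=[N+]([O-])c1ccc2[nH]c(CSCc3nc4ccccc4[nH]3)nc2c1`: 13100 nM
- compound 2 `O=[N+]([O-])c1ccc2[nH]c(CSCc3nc4cc([N+](=O)[O-])ccc4[nH]3)nc2c1`: 1740 nM
- compound 3 `O=C(CSCc1nc2cc([N+](=O)[O-])ccc2[nH]1)c1ccccc1`: 18600 nM

Compound 3, at 18600 nM, lies within the usual scatter of compound 1 and well above compound 2, which has the lowest number of the three. The next molecule, compound 4 `O=C(CSCc1nc2cc([N+](=O)[O-])ccc2[nH]1)c1ccc(Br)cc1`, keeps all of compound 3 but turns its phenyl into 4-bromophenyl, with bromo in place of hydrogen on an aromatic carbon, para to a large group: bromo in place of hydrogen on an aromatic carbon.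

Among the compounds with values here, no measured step involves bromo. The closest guide is a 7.5-fold lower number from compound 1 to compound 2 (0.88 log units; beyond the scatter), where nitro replaces hydrogen on an aromatic carbon. That step concerns a different group on a different part of the molecule, so it supports only a cautious expectation in this assay: a small move toward a lower number, perhaps none beyond the scatter.

The expected change is a 1.9-fold lower number from compound 3 to compound 4 (0.27 log units; within the scatter). For compound 4 the estimated value is 10000 nM, with an expected range from 4000 nM to 25000 nM.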

Compound 4, half-maximal inhibitory concentration: 1550 nM
The estimate for compound 4 lay 6.5-fold (0.81 log units) above the measured number; measured number below the stated range.
By their numbers in this assay, from the lowest: compounds 4 and 2 (each within the scatter of the next); then compounds 1 and 3 (each within the scatter of the next).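

In this assay, adding one bromo atom to the phenyl ring, para to a large group, gives a 12-fold lower number from compound 3 to compound 4 (1.08 log units; beyond the scatter), a large step. Within the data shown here, until now the only readable step was a 7.5-fold lower number from compound 1 to compound 2 (0.88 log units; beyond the scatter), where nitro entered a different part of the molecule, so this result shows that the phenyl ring of compound 3 is also a place where one added atom moves the number well beyond the scatter. No measurement shown here explains why bromo has this effect.

From the compounds shown here alone, it remains open whether this change is specific to bromo or would also appear with chloro, methoxy or an amine in the same place. It is also unknown whether bromo elsewhere on the phenyl ring would give a similar step.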